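Notes on a chloro-to-anilino change in the quinazolinone series

This account rests on a few compounds, and the source may have more. Where it says the series, first, only, none or still open, it means among the compounds named here.

Of the compounds shown here, three of the shared core have been measured in a functional assay on the whole organism (strain albino) for inhibition, with Rattus norvegicus as the target, read by paw edema, with stated times of 1 h and 3 h, at a dose of 100 mg/kg by the oral route; a higher number here means a stronger effect of the compound at the dose given, a lower number a weaker effect. Compound 1 `Cn1c(SCC(=O)Nn2c(COc3ccc(Cl)cc3Cl)nc3ccccc3c2=O)nc(-c2ccc(Cl)cc2)c(C#N)c1=O` gives 73.7%. Compound 2 `N#Cc1c(Cl)nc(SCC(=O)Nn2c(COc3ccc(Cl)cc3Cl)nc3ccccc3c2=O)nc1-c1ccc(Cl)cc1` gives 68.4%, and compound 3 `N#Cc1c(Cl)nc(SCC(=O)Nn2c(COc3ccc(Cl)cc3Cl)nc3ccccc3c2=O)nc1-c1ccc(O)cc1` gives 73.7%. Compound 3 thus stands level with compound 1 at the digits printed, the two together the highest of the three numbers, with compound 2 within the scatter of both. For the measured compounds named here, the single step with a change in one place is a number 5.3 percentage points higher from compound 2 to compound 3 (within the scatter).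

Compound 4 `N#Cc1c(Nc2ccc(O)cc2)nc(SCC(=O)Nn2c(COc3ccc(Cl)cc3Cl)nc3ccccc3c2=O)nc1-c1ccc(O)cc1` differs from compound 3 in one place: (4-hydroxyphenyl)amino in place of chloro on an aromatic carbon. Going by the values given here, no measured step touches that place, and the only step at hand was within the scatter, so no change beyond the scatter is expected in this assay. The step is expected to be a number 1.7 percentage points lower from compound 3 to compound 4 (within the scatter). Compound 4 is estimated at 72%, within 60% to 82%.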

Compound 4, a percentage reported as inhibition, in the whole organism at one dose (the size of the read-out at that dose, not a potency): 86.8%
The estimate for compound 4 lay 14.8 percentage points below the measured number, and the stated range ends below it.
By their numbers in this assay, from the lowest: compounds 2, 1 and 3 (each within the scatter of the next); then compound 4.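

For the compounds shown here, the place next to the ring nitrogen and ortho to a cyano group gives the first step beyond the scatter: in this assay, (4-hydroxyphenyl)amino in place of chloro gives a number 13.1 percentage points higher from compound 3 to compound 4 (beyond the scatter). The position therefore accepts a much larger group, with its own aromatic ring and hydrogen-bond donors, without loss of the read-out at this dose. Nothing at hand bears on why the number rises.

Which part of the entering group carries the step remains open. A plain anilino group, a morpholine or a short alkylamine at this place would help separate the contributions of the ring, the hydroxy group and the nitrogen.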